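Isopropyl for cyclopropyl on the aryl piperazine

A few compounds are considered here, and "the series" means these few. Any claim that something is new, unique, unknown or untested is made for them only; others in the source may bear on it.

Compound 2 `CN(C)C(=O)c1cccnc1NCCCN1CCN(c2ccccc2C2CC2)CC1` gives 63.1 nM in a functional assay on aorta for antagonist activity at Alpha-1D adrenergic receptor (Rattus norvegicus) (a higher number here means weaker binding, a lower number tighter binding), and compound 1 `CN(C)C(=O)c1cccnc1NCCCN1CCN(c2ccccc2Cc2ccccc2)CC1` gives 79.4 nM; the two numbers lie within the scatter of each other, as the step of a 1.3-fold lower number from compound 1 to compound 2 (0.10 log units; within the scatter) shows. Compound 3 `CC(C)c1ccccc1N1CCN(CCCNc2ncccc2C(=O)N(C)C)CC1` differs from compound 2 by isopropyl in place of cyclopropyl on an aromatic carbon. For the measured compounds named here, the only step measured at this place, from benzyl to cyclopropyl, stayed within the scatter, so the exchange of cyclopropyl for isopropyl is expected to move this assay little as well, with the estimated step of a 1.1-fold higher number from compound 2 to compound 3 (0.05 log units; within the scatter). Compound 3 is therefore expected to give about 70 nM, within a range of 28 nM to 180 nM.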

Compound 3, dissociation constant: 63.1 nM
The estimate for compound 3 lay 1.1-fold (0.05 log units) above the measured number, within the range that was stated.
By their numbers in this assay, from the lowest: compounds 2, 3 and 1 (each within the scatter of the next).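

With isopropyl in place of cyclopropyl at this position on the aromatic ring, the ring of cyclopropyl proves dispensable in this assay (no change at the digits printed from compound 2 to compound 3 (within the scatter)). Benzyl, cyclopropyl and isopropyl all read alike here, as the further step shows (a 1.3-fold lower number from compound 1 to compound 3 (0.10 log units; within the scatter)), so no difference among these three groups has yet appeared at this place. Nothing measured here explains this sameness. On these data alone, all three groups contain only carbon and hydrogen, so it remains open whether an amine, a carboxylic acid or a methoxy group at this place would also leave the number within the scatter.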